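Thiourea series: aryl swap on the cyclic urea nitrogen

The compounds below may be only part of what the source reports. "The series", "measured", "known", "first", "only" and "open" are said of these compounds alone.

Measured so far:
compound 1 `NC(=S)Nc1cccc(OCCCCCN2CCN(c3ccc(Cl)cc3)C2=O)c1` — 39000 nM
compound 2 `NC(=S)Nc1cccc(OCCCCCN2CCN(c3cccc4ccccc34)C2=O)c1` — 15000 nM

Among the measured compounds shown here, in an ADME assay on Huh-7 cells (Homo sapiens) for cytotoxicity (on this read-out lower numbers stand for higher toxicity in this test and higher numbers for lower toxicity in this test), compound 1 gives 39000 nM and stands as the higher of the two numbers; the only measured step is a 2.6-fold lower number from compound 1 to compound 2 (0.41 log units; beyond the scatter). Compound 3 `NC(=S)Nc1cccc(OCCCCCN2CCN(c3ccc(Oc4ccccc4)cc3)C2=O)c1` differs from compound 1 by phenoxy in place of chloro on an aromatic carbon. For the measured compounds named here, no measured pair changes this position, so the step from compound 1 to compound 2 is the only guide, and it concerns a different part of the same aryl group. A modest lowering is therefore expected, a 1.6-fold lower number from compound 1 to compound 3 (0.19 log units; within the scatter), with compound 3 estimated at 25000 nM (range 10000 nM to 60000 nM).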

Compound 3, half-maximal cytotoxic concentration: > 50000 nM
Compound 3 gave a limit, no number; the forecaster's own chance of this, stated with the estimate: 20%; middle value at least 2.0-fold (0.30 log units) from the limit.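

In this assay, among the compounds shown here, phenoxy in place of chloro gives an at least 1.2-fold higher number from compound 1 to compound 3 (0.10 log units; that floor lies within the scatter), so the lowering seen in a 2.6-fold lower number from compound 1 to compound 2 (0.41 log units; beyond the scatter) has no counterpart with this change. This aromatic carbon, para to a large group, thus carries a phenoxy group, with its extra six-membered aromatic ring, without a lower number. The result for compound 3 is a limit and not a number: the limit of > 50000 nM in this assay, at which 1 of the 3 values shown sits.

Going by these compounds, how far compound 3 lies past that limit stays open. Also open, on these data alone, is whether an amine or a carboxylic acid on this carbon would give a similarly high number.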